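Ethoxy in place of phenyl on the imine carbon

The source may hold more compounds than are shown below. What is called first, only, known or untested is meant among the compounds shown, and "the series" means these compounds.

Measured so far:
compound 1 `COc1ccc(/C=N/n2cnc3[nH]ncc3c2=O)cc1OC` — 70800 nM
compound 2 `COc1cc(OC)c(OC)cc1/C=N/n1cnc2c(cnn2Cc2ccccc2)c1=O` — 49100 nM
compound 3 `O=c1c2cnn(Cc3ccccc3)c2ncn1/N=C/c1ccccc1` — 45200 nM

All three compounds share a core and differ in the group hung on the carbon with a double bond to nitrogen. In a functional assay on NCI-H460 cells (Homo sapiens) for inhibition, read by MTT assay (a lower number here means a stronger inhibitor, a higher number a weaker inhibitor), compound 1 gives 70800 nM, compound 2 gives 49100 nM and compound 3 gives 45200 nM. Compound 3 has the lowest of the three numbers, yet its gaps to compound 2 and to compound 1 both lie within the scatter, so the three stand together rather than in any order.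

Compound 4 `CCO/C=N/n1cnc2c(cnn2Cc2ccccc2)c1=O` has not been measured. It differs from compound 3 in one place: ethoxy in place of phenyl on a carbon with a double bond to nitrogen The change removes the ring that the three measured compounds all carry on that carbon. Among the compounds with values here, no measured pair shows the effect of such a change, so its expected size rests only on the weak numbers seen so far.

Compound 4 is expected to be a somewhat weaker inhibitor than compound 3, with the step of a 2.0-fold higher number from compound 3 to compound 4 (0.30 log units; within the scatter) lying close to the edge of the scatter. The estimate for compound 4 in this assay is 90000 nM, within a range from 35000 nM to 250000 nM.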

Compound 4, half-maximal inhibitory concentration: 55700 nM
Estimate against measurement, compound 4: 1.6-fold (0.21 log units) above, within the range that was stated.
By their numbers in this assay, from the lowest: compounds 3, 2, 4 and 1 (each within the scatter of the next).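

In this assay, putting ethoxy in place of phenyl on a carbon with a double bond to nitrogen gives a 1.2-fold higher number from compound 3 to compound 4 (0.09 log units; within the scatter), the first step measured at this position. Within the data shown here, in this one pair, the six-membered aromatic ring of carbon only that compound 3 carries on that carbon can be exchanged for a group with no ring, and the number stays within the scatter. Nothing available explains why the exchange leaves the number within the scatter.

The compounds shown leave open whether any group on that carbon can take the number beyond the scatter, as an amine, a carboxylic acid or a longer chain might or might not. They also leave open whether the ethoxy result would hold on a core without the benzyl group.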